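Compound 3 to Compound 4: A Benzoyl Group Enters

A few compounds are considered here, and "the series" means these few. Any claim that something is new, unique, unknown or untested is made for them only; others in the source may bear on it.

Compound 1 `C=CCn1c(SCC(=O)c2ccccc2)nnc1-c1ccc(OC)c(OC)c1`: in a functional assay on the whole organism (strain albino) for inhibition, with Rattus norvegicus as the target, read by paw edema, with a stated time of 3 h, at a dose of 0.28 mmol/kg by the oral route (on this read-out lower numbers stand for less inhibition and higher numbers for more inhibition at the one dose given (going by the name of the read-out)), compound 1 gives 64%.
Compound 2 `CCn1c(SCC(=O)c2ccccc2)nnc1-c1cc(OC)c(OC)c(OC)c1`: in this assay compound 2 gives 49%.
Compound 3 `C=CCn1c(SC/C(=N/O)c2ccccc2)nnc1-c1cc(OC)c(OC)c(OC)c1`: in this assay compound 3 gives 70%.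

Among the three measured compounds, compound 3 carries the highest number in this assay. Its nearest neighbour is compound 1, whose number lies within the usual scatter of compound 3, so no order between those two can be claimed. Compound 2 stands furthest away, with a number beyond the scatter below that of compound 3.

Compound 4 `C=CCn1c(SCC(=O)c2ccccc2)nnc1-c1cc(OC)c(OC)c(OC)c1` has not yet been measured. Relative to compound 3 it differs in one place: a group of 8 heavy atoms (7 carbon, 1 oxygen; one six-membered aromatic ring of carbon only) in place of a group of 9 heavy atoms (7 carbon, 1 nitrogen, 1 oxygen; one six-membered aromatic ring of carbon only), on a saturated chain carbon bound to a sulfur. The rest of the shared core and the groups on it are kept unchanged.

Going by the values given here, no step between two measured compounds isolates this change, so the expectation rests on the spread of the three numbers as a whole. Compound 4 is expected to fall somewhere among the measured values, with a step of a number 10 percentage points lower from compound 3 to compound 4 (within the scatter) from compound 3 that is estimated to be modest, downward, and not clearly beyond the scatter. The estimate for compound 4 in this assay is 60%, with a range from 45% to 75%.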

Compound 4, a percentage reported as inhibition, in the whole organism at one dose (the size of the read-out at that dose, not a potency): 66%
Estimate against measurement, compound 4: 6 percentage points below; measured number inside the range.
By their numbers in this assay, from the lowest: compound 2; then compounds 1, 4 and 3 (each within the scatter of the next).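

In this assay, benzoyl in place of the group leaving compound 3, on a saturated chain carbon bound to a sulfur, gives a number 4 percentage points lower from compound 3 to compound 4 (within the scatter) and so shows that this single change at this position has no effect that can be read apart from the usual scatter. Compound 4 also links to the other compounds, and vinyl in place of methyl on a saturated chain carbon bound to an aromatic nitrogen gives a number 17 percentage points higher from compound 2 to compound 4 (beyond the scatter), a modest step and the only one of the three that clears the scatter. Methoxy in place of hydrogen on an aromatic carbon gives a number 2 percentage points higher from compound 1 to compound 4 (within the scatter), so this added group likewise leaves no readable mark on the number at the one dose given.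

No measurement shown bears on why the numbers fall as they do.

From the compounds shown here alone, it remains open whether a carboxylic acid or an amine on the saturated chain carbon bound to a sulfur would keep the number where compound 3 and compound 4 stand. Going by these compounds, it is equally open whether a longer chain on the saturated chain carbon bound to an aromatic nitrogen would extend or lose what the vinyl step shows.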